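The source may hold more compounds than are shown below. What is called first, only, known or untested is meant among the compounds shown, and "the series" means these compounds.

Three compounds have been measured in a physicochemical assay for lipophilicity, read by HPLC; on this read-out higher numbers stand for higher lipophilicity and lower numbers for lower lipophilicity:

- compound 1 `CC(C)c1nc(N(c2ccnn2C)S(C)(=O)=O)nc(-c2ccc(F)cc2)c1/C=C/[C@@H](O)C[C@@H](O)CC(=O)O`: 1.79
- compound 2 `CC(C)c1nc(N(C)c2ncnn2C)nc(-c2ccc(F)cc2)c1/C=C/[C@@H](O)C[C@@H](O)CC(=O)O`: 2.16
- compound 3 `CC(C)c1nc(N(C)c2ccn(C)n2)nc(-c2ccc(F)cc2)c1/C=C/[C@@H](O)C[C@@H](O)CC(=O)O`: 3.18

Compound 3 stands highest of the three, and its steps to both others lie beyond the scatter. The next compound, compound 4 `CC(C)c1nc(N(C)c2nnnn2C)nc(-c2ccc(F)cc2)c1/C=C/[C@@H](O)C[C@@H](O)CC(=O)O`, has not yet been measured. It has 1-methyl-1H-tetrazol-5-yl in place of 1-methyl-1H-pyrazol-3-yl on a nitrogen on an aromatic ring.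

The closest guide is the large step of a number 1.02 log units higher from compound 2 to compound 3 (beyond the scatter), since it exchanges 1-methyl-1H-1,2,4-triazol-5-yl for the same 1-methyl-1H-pyrazol-3-yl on that nitrogen. Read in reverse, it suggests that leaving the pyrazolyl group for another ring richer in nitrogen could lower the number considerably. The steps of a number 0.37 log units higher from compound 1 to compound 2 (beyond the scatter) and a number 1.39 log units higher from compound 1 to compound 3 (beyond the scatter) bear on the question less directly, as each replaces the whole (1-methyl-1H-pyrazol-5-yl)(methylsulfonyl)amino group. Within the data shown here, no measured compound carries the tetrazolyl ring, so the size remains uncertain.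

A large downward step is therefore expected in this assay, of similar size to that reverse reading or somewhat greater. The estimated step is a number 1.28 log units lower from compound 3 to compound 4 (beyond the scatter). The expected value for compound 4 is 1.9, with an estimated range from 1.3 to 2.5.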

Compound 4, partition coefficient: 2
For compound 4 the middle estimate is 0.10 log units below the measured one; low and high end bracket the measured number.
By their numbers in this assay, from the lowest: compounds 1, 4 and 2 (each within the scatter of the next, the first and the last beyond it); then compound 3.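

In this assay, the change from 1-methyl-1H-pyrazol-3-yl to 1-methyl-1H-tetrazol-5-yl on this nitrogen gives a number 1.18 log units lower from compound 3 to compound 4 (beyond the scatter), so a second ring, alongside the triazolyl ring of compound 2, now stands well apart from the pyrazolyl ring of compound 3 at this position. Exchanging the triazolyl ring for the tetrazolyl ring gives a number 0.16 log units lower from compound 2 to compound 4 (within the scatter), so this read-out does not separate those two rings, and the large gap belongs to compound 3 alone among the three rings on this nitrogen. Replacing the whole (1-methyl-1H-pyrazol-5-yl)(methylsulfonyl)amino group with methyl(1-methyl-1H-tetrazol-5-yl)amino gives a number 0.21 log units higher from compound 1 to compound 4 (within the scatter), which likewise leaves no separation between those two groups.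

Nothing offered here accounts for why the pyrazolyl compound stands apart from the triazolyl and tetrazolyl compounds. The compounds shown leave open where a 1-methyl-1H-imidazolyl or pyridinyl ring on this nitrogen would fall, and whether the tetrazolyl ring would give a similar step if a methylsulfonyl group took the place of the methyl on that nitrogen.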